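Phenyl for dibromophenyl on the amide carbonyl: cytotoxicity notes

The compounds below may be only part of what the source reports. "The series", "measured", "known", "first", "only" and "open" are said of these compounds alone.

Measured so far:
compound 1 `O=C(Nc1ccc(Sc2nc3ccccc3s2)c(Cl)c1)c1cc(Br)cc(Br)c1` — a limit only, > 100000 nM
compound 2 `O=C(Nc1cccc(Cl)c1)c1cccc(Br)c1` — 51000 nM
compound 3 `O=C(Nc1ccccc1)c1cc(Br)cc(Br)c1O` — 34000 nM

In an ADME assay on HEK293 cells (Homo sapiens) for cytotoxicity, read by reporter gene assay and resazurin assay, with a stated time of 48 h (on this read-out higher numbers stand for lower toxicity in this test and lower numbers for higher toxicity in this test), compound 1 sits at the limit of the assay (the limit of > 100000 nM in this assay, at which 1 of the 3 values shown sits), so its own number is not known. Compound 4 `O=C(Nc1ccc(Sc2nc3ccccc3s2)c(Cl)c1)c1ccccc1` differs from compound 1 in one place: phenyl in place of 3,5-dibromophenyl on a carbonyl carbon. For the measured compounds named here, no step between measured compounds covers this change, and the values of compound 2 and compound 3, which carry fewer or no bromines on that ring with a smaller anilide part, give no direct guide for the shared core of compound 1. The step from compound 1 to compound 4 in this assay is expected to be small, no more than the usual scatter, giving an at least 1.4-fold lower number from compound 1 to compound 4 (0.15 log units; that floor lies within the scatter). Compound 4 is therefore estimated at 70000 nM, between 25000 nM and 200000 nM, with a fair chance that only a limit is reported again.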

Compound 4, half-maximal cytotoxic concentration: 90000 nM
Beside the measured number, compound 4's estimate is 1.3-fold (0.11 log units) below it; measured number inside the range.
By their numbers in this assay, from the lowest: compounds 3, 2 and 4 (each within the scatter of the next, the first and the last beyond it). At a limit, above all of these: compound 1.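

On the shared core, this assay gives an at least 1.1-fold lower number from compound 1 to compound 4 (0.04 log units; that floor lies within the scatter) for phenyl in place of 3,5-dibromophenyl on a carbonyl carbon, a reading with the anilide part held fixed that compound 2 and compound 3 could not give. On these data alone, compound 1 remains a limit, not a number: the limit of > 100000 nM in this assay, at which 1 of the 4 values shown sits. The step is therefore only a floor, and its true size stays unknown.

As far as these compounds go, whether an amine or a carboxylic acid on the phenyl ring of compound 4 would shift the number beyond the scatter stays open.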